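This account rests on a few compounds, and the source may have more. Where it says the series, first, only, none or still open, it means among the compounds named here.

Of the compounds shown here, two with a shared core have been measured so far, and a third waits for its result. Compound 1 `Cc1cccc(CNC(=O)/C=C/c2ccc(O)c(O)c2)c1` carries a methyl group on its outer ring; compound 2 `COc1ccc(CNC(=O)/C=C/c2ccc(O)c(O)c2)cc1` carries a methoxy group instead. In an ADME assay on B16 cells (Mus musculus) for cytotoxicity, read by MTT assay, tested at 20 uM (on this read-out higher numbers stand for a stronger effect at the one concentration tested and lower numbers for a weaker effect), compound 1 gives 45%, while compound 2 gives 20%. Compound 1 therefore stands highest of the two numbers, and the gap to compound 2 lies beyond the usual scatter of such measurements.

The next compound, compound 3 `O=C(/C=C/c1ccc(O)c(O)c1)NCc1cccc(Cl)c1`, is reached from compound 1 by a single change: chloro in place of methyl on an aromatic carbon. One heavy atom leaves and one heavy atom enters at the same aromatic carbon, with no change in ring count, hydrogen-bond donors, acceptors or charge. Within the data shown here, no pair of measured compounds shows this kind of exchange, so there is no measured step to lean on; only the value of compound 1 in this assay, 45%, sets the starting point.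

Given this, the step from compound 1 to compound 3 is expected to be small, a number 3 percentage points higher from compound 1 to compound 3 (within the scatter), not beyond the scatter in either direction. Compound 3 is estimated at 48%, with a range from 30% to 66%.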

Compound 3, a percentage reported as activity, at one concentration (the size of the read-out at that concentration, not a potency): 59%
For compound 3 the middle estimate is 11 percentage points below the measured one; measured number inside the range.
By their numbers in this assay, from the lowest: compound 2; then compound 1; then compound 3.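

Going from 3-methylphenyl to 3-chlorophenyl gives a number 14 percentage points higher from compound 1 to compound 3 (beyond the scatter) in this assay, the first measured step in this set in which only one group changes. This shows that the read-out at the one concentration tested responds to what sits on this aromatic carbon, meta to a large group, even when one heavy atom simply replaces another and the ring count, hydrogen-bond donors, hydrogen-bond acceptors and charge stay the same. Nothing measured here explains why this exchange has this effect.

A single exchange gives one step rather than a trend, so the compounds shown leave open whether bromo, trifluoromethyl, an amine or a carboxylic acid at the same carbon would raise the number further or lower it. They also leave open whether chloro would give a similar step at other carbons of the outer ring, and whether the order of compound 1 and compound 3 would hold at other concentrations.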